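Changing the Aryl Group on an Aromatic Nitrogen

The source may hold more compounds than are shown below. What is called first, only, known or untested is meant among the compounds shown, and "the series" means these compounds.

Measured compounds:
compound 1, `CCOc1ccccc1-n1nncc1CN1C(=O)C2(C(C#N)=C(N)Oc3c2c2nc4ccccc4nc2c2ccccc32)c2ccccc21`: > 50000 nM
compound 2, `N#CC1=C(N)Oc2c(c3nc4ccccc4nc3c3ccccc23)C12C(=O)N(Cc1cnnn1-c1cccc(S(N)(=O)=O)c1)c1ccccc12`: 38600 nM
compound 3, `N#CC1=C(N)Oc2c(N)cc3nc4ccccc4nc3c2C12C(=O)N(Cc1cnnn1-c1cccc(C(F)(F)F)c1)c1ccccc12`: > 50000 nM

These three compounds share a core and were tested in an ADME assay on HUVEC cells (Homo sapiens) for antiproliferative activity, read by MTT assay, with a stated time of 48 h; a lower number here means a stronger inhibitor, a higher number a weaker inhibitor. For compound 1 the value > 50000 nM is a limit of the assay, not a number. Compound 2 gives 38600 nM, a measured number. For compound 3 the value > 50000 nM is again a limit of the assay. Two of the three values shown sit at the limit (the limit of > 50000 nM in this assay, at which 2 of the 3 values shown sit), and compound 3 is one of them, so its place is known only as being at that limit, with no number to pin it down.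

The new compound 4, `COc1cc(-n2nncc2CN2C(=O)C3(C(C#N)=C(N)Oc4c(N)cc5nc6ccccc6nc5c43)c3ccccc32)c(OC)cc1Cl`, differs from compound 3 in one place: 4-chloro-2,5-dimethoxyphenyl in place of 3-(trifluoromethyl)phenyl on an aromatic nitrogen. Among the measured compounds shown here, the only measured step of a comparable kind, an aryl group exchanged on an aromatic nitrogen, is an at least 1.2-fold lower number from compound 1 to compound 2 (0.11 log units; that floor lies within the scatter). Nothing else among the measured compounds bears on this change. The expected step is therefore a number no higher from compound 3 to compound 4 (the limit leaves the size open), nothing beyond the scatter. Compound 4 is expected at 50000 nM, within 20000 nM to 120000 nM, and the assay will most likely again report only a limit.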

Compound 4, half-maximal inhibitory concentration: > 50000 nM
Compound 4 gave a limit, no number; the forecaster's own chance of this, stated with the estimate: 70%; the middle value sits exactly at the limit.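

Compound 3 and compound 4 each give only a limit of the assay, not a number, so the step between them cannot be read: the limit of > 50000 nM in this assay, at which 3 of the 4 values shown sit.

The compounds shown leave open whether 4-chloro-2,5-dimethoxyphenyl or 3-(trifluoromethyl)phenyl gives the lower number in this assay.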